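A few compounds are considered here, and "the series" means these few. Any claim that something is new, unique, unknown or untested is made for them only; others in the source may bear on it.

Compound 1 `Cc1cn(C2CC(N=[N+]=[N-])C(COC(=O)CCCC(=O)OC(C)(C)C)O2)c(=O)[nH]c1=O`, compound 2 `Cc1cn(C2CC(N=[N+]=[N-])C(COC(=O)NCCCO)O2)c(=O)[nH]c1=O` and compound 3 `Cc1cn(C2CC(N=[N+]=[N-])C(COC(=O)NCCCC(=O)OC(C)(C)C)O2)c(=O)[nH]c1=O` share one core and differ only in the group attached to the carbonyl carbon of the side chain. In an ADME assay on the whole organism (serum) with Homo sapiens as the target (on this read-out lower numbers stand for a shorter-lived compound and higher numbers for a longer-lived compound), compound 1 gives 0.55 h. For compound 2 this assay reports only a limit, > 48 h. For compound 3 this assay likewise reports only a limit, > 48 h. Going by the values given here, the one readable step is an at least 87-fold higher number from compound 1 to compound 2 (1.94 log units; beyond the scatter); the following step, a step that the two limits leave unreadable from compound 2 to compound 3, cannot be sized. Compound 2 thus stands at the limit of > 48 h in this assay, at which 2 of the 3 values shown sit, with compound 3 beside it there, while compound 1 alone lies well short of that limit.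

Among the compounds with values here, compound 4 `Cc1cn(C2CC(N=[N+]=[N-])C(COC(=O)OCCCN)O2)c(=O)[nH]c1=O` remains to be measured. 3-aminopropoxy in place of (3-hydroxypropyl)amino on a carbonyl carbon No measured step covers this rearrangement: the readable step from compound 1 to compound 2 exchanges 3-(tert-butoxycarbonyl)propyl for (3-hydroxypropyl)amino on the carbonyl carbon and moves the read-out sharply upward, and the step from compound 2 to compound 3 is unreadable. Within the data shown here, for compound 4 the expectation is a downward step an at least 9.6-fold lower number from compound 2 to compound 4 (0.98 log units; beyond the scatter), the direction taken from compound 1 0.55 h as the only short-lived member. Compound 4 is estimated at 5 h, within 1 h to 30 h.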

Compound 4, half-life: 0.133 h
Compound 4: the middle estimate sits 38-fold (1.58 log units) above what was measured; the whole stated range lies above it.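

The same atoms, joined differently, are enough to shift the read-out at this position: in this assay, placing 3-aminopropoxy instead of (3-hydroxypropyl)amino on the carbonyl carbon gives an at least 360-fold lower number from compound 2 to compound 4 (2.55 log units; beyond the scatter), so the composition of the side chain alone does not set the half-life. A tert-butoxycarbonyl end is also not required for a short half-life, as the series shows a 4.1-fold lower number from compound 1 to compound 4 (0.62 log units; beyond the scatter). Across the compounds shown, the short-lived members, compound 1 and compound 4, lack an amide-type nitrogen on the carbonyl carbon, whereas compound 2 and compound 3, which carry one, stay at the assay limit: the limit of > 48 h in this assay, at which 2 of the 4 values shown sit.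

The step between the two compounds at the limit cannot be read, so the series gives no ranking of their end groups. Going by these compounds, it also remains open whether the low half-life of compound 4 follows from the oxygen on the carbonyl carbon or from the terminal amine, a question that 3-hydroxypropoxy or (3-aminopropyl)amino on the same carbonyl carbon would help to separate.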